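Stepping from compound 1 to compound 4

The source may hold more compounds than are shown below. What is called first, only, known or untested is meant among the compounds shown, and "the series" means these compounds.

In an ADME assay on THP-1 cells (Homo sapiens) for cytotoxicity, read by trypan blue exclusion, with a stated time of 24 h (on this read-out higher numbers stand for weaker inhibition and lower numbers for stronger inhibition), compound 1 (`N#C[Se]Cc1ccc([N+](=O)[O-])cc1`) gives 16800 nM. Compound 2 (`N#C[Se]Cc1ccc(Br)cc1`) gives 28900 nM, and compound 3 (`N#C[Se]Cc1ccc(C#N)cc1`) gives 7970 nM. Compound 1 thus has one close neighbour and one that stands clearly apart, with a 1.7-fold higher number from compound 1 to compound 2 (0.24 log units; within the scatter) and a 2.1-fold lower number from compound 1 to compound 3 (0.32 log units; beyond the scatter).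

Compound 4 (`N#C[Se]CCc1ccc([N+](=O)[O-])cc1`) keeps the nitro group and differs elsewhere: a group of 4 heavy atoms (2 carbon, 1 nitrogen, 1 selenium; no ring) in place of a group of 3 heavy atoms (1 carbon, 1 nitrogen, 1 selenium; no ring), on a saturated chain carbon bound to an aromatic carbon. Among the compounds with values here, none of the measured steps touches that place. Each one swaps a group on an aromatic carbon, and the largest is a 3.6-fold lower number from compound 2 to compound 3 (0.56 log units; beyond the scatter). These steps show how far numbers move within this small series, but they say nothing direct about the new change. Within the data shown here, with no measured step to suggest a direction, no shift beyond the scatter is expected, and the value of compound 1 at 16800 nM remains the best guide. The expected change is small, a 1.0-fold higher number from compound 1 to compound 4 (0.01 log units; within the scatter). The range is kept wide, since a move of the size of a 3.6-fold lower number from compound 2 to compound 3 (0.56 log units; beyond the scatter) in either direction cannot be ruled out. For compound 4, the estimated value in this assay is 17000 nM, with an expected range from 6500 nM to 42000 nM.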

Compound 4, half-maximal inhibitory concentration: 17200 nM
Estimate against measurement, compound 4: 1.0-fold (0.01 log units) below; the range from low to high includes it.
By their numbers in this assay, from the lowest: compound 3; then compounds 1, 4 and 2 (each within the scatter of the next).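

In this assay, putting the group of 4 heavy atoms in place of the group of 3 heavy atoms, on a saturated chain carbon bound to an aromatic carbon, gives a 1.0-fold higher number from compound 1 to compound 4 (0.01 log units; within the scatter), so with the nitro group kept, this change leaves the number where it was. The earlier compounds shown here could not show this, since each of their steps swaps a group on an aromatic carbon, and such a swap can move the number beyond the scatter, as in a 3.6-fold lower number from compound 2 to compound 3 (0.56 log units; beyond the scatter); the chain is now seen to be a place where one change, in one pair of compounds, produced no such move. No separate measurement is available to explain the result, so this remains an observation and not an account of how it arises.

One pair cannot show whether the same change would also make no difference with the bromo group of compound 2 or the cyano group of compound 3. It also leaves open what this assay would report for a longer chain at this place, or for an amine or a carboxylic acid in place of the selenium-bearing group.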